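One More Fluoro on a Compound Held at the Limit

This account rests on a few compounds, and the source may have more. Where it says the series, first, only, none or still open, it means among the compounds named here.

Measured so far:
compound 1, `COc1ccc2c(=O)c(/C=C/C(=O)NCc3ccc(F)cc3)coc2c1`: > 100000 nM
compound 2, `O=C(/C=C/c1coc2cc(O)ccc2c1=O)NCc1ccc(F)cc1`: > 100000 nM
compound 3, `COc1ccc(NC(=O)/C=C/c2coc3cc(O)ccc3c2=O)cc1`: 12800 nM

In a functional assay on A549 cells (Homo sapiens) for inhibition, read by MTT assay, with a stated time of 48 h (on this read-out lower numbers stand for stronger inhibition and higher numbers for weaker inhibition), compound 1 reports only a limit of the assay, > 100000 nM. Compound 2 also sits at a limit, > 100000 nM. Compound 3 gives a number, 12800 nM. Between them lie a step that the two limits leave unreadable from compound 1 to compound 2 and an at least 7.8-fold lower number from compound 2 to compound 3 (0.89 log units; beyond the scatter). Compound 4, `COc1ccc2c(=O)c(/C=C/C(=O)NCc3ccc(F)cc3F)coc2c1`, differs from compound 1 by fluoro in place of hydrogen on an aromatic carbon, 4-fluorobenzyl becoming 2,4-difluorobenzyl. Neither measured step changes a fluoro on an aromatic carbon, so none bears directly on it; what stands out is the limit of > 100000 nM in this assay, at which 2 of the 3 values shown sit. The expected step is therefore a number no higher from compound 1 to compound 4 (the limit leaves the size open), none beyond the scatter. Compound 4 is estimated at 100000 nM, within 30000 nM to 300000 nM, most likely again reported only as a limit.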

Compound 4, half-maximal inhibitory concentration: 13300 nM
Compound 4: the middle estimate sits 7.5-fold (0.88 log units) above what was measured; measured number below the stated range.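

In this assay, fluoro in place of hydrogen on an aromatic carbon, ortho to a large group, gives an at least 7.5-fold lower number from compound 1 to compound 4 (0.87 log units; beyond the scatter). Among the compounds shown here, this is the first sign that this position on the 4-fluorobenzyl group answers to a single added atom, and 2,4-difluorobenzyl gives compound 4 a readable number. The size of the step stays open on one side, because compound 1 reports only a limit: the limit of > 100000 nM in this assay, at which 2 of the 4 values shown sit.

The compounds shown leave open whether chloro, methoxy or an amine at this position would act alike. They also leave open whether the same fluoro would change the hydroxy compound 2.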